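The source may report more compounds than this note shows. Statements on the series, on what has been measured and on what is new or still open speak of the compounds shown alone.

Working notes on the series.

Three compounds have numbers in a functional assay on KB cells (Homo sapiens) for cytotoxicity; a higher number here means that more compound is tolerated, a lower number that less compound is tolerated. Compound 1, `Nc1nc2c(ncn2[C@@H]2O[C@H](CO)[C@@H](O)[C@H]2O)/c(=N\O)[nH]1`, gives 281000 nM. Compound 3, `Nc1nc2[nH]cnc2/c(=N\O)[nH]1`, gives 45000 nM. Compound 2, `ONc1ncnc2[nH]cnc12`, gives 1490000 nM, the highest of the three: it is separated from compound 1 and from compound 3 by gaps that lie beyond the scatter, so compound 2 is the one whose concentration is best tolerated by the cells among those measured. Among the compounds with values here, compound 1 and compound 3 carry the shared core with a different substituent pattern; no single-change pair among the measured compounds exists, so nothing about the effect of any one change can be read from the numbers so far.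

The unmeasured compound 4, `NNc1ncnc2[nH]cnc12`, differs from compound 2 in one place: amino in place of hydroxy on a nitrogen on an aromatic ring. Nothing measured bears on this change. Within the data shown here, with no comparable step to draw on, the expectation for the step from compound 2 to compound 4 is small, a 1.5-fold lower number from compound 2 to compound 4 (0.17 log units; within the scatter), most likely within the scatter, with a lean toward a slightly lower number. Compound 4 is therefore estimated at 1000000 nM in this assay, within a range from 300000 nM to 3000000 nM.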

Compound 4, half-maximal cytotoxic concentration: 49300 nM
Compound 4: middle estimate off by 20-fold (1.31 log units), on the high side, outside the stated range (below it).
By their numbers in this assay, from the lowest: compounds 3 and 4 (each within the scatter of the next); then compound 1; then compound 2.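

Within the data shown here, the first single-change pair gives a reading at this position: in this assay, amino in place of hydroxy on a nitrogen on an aromatic ring gives a 30-fold lower number from compound 2 to compound 4 (1.48 log units; beyond the scatter) and shows that exchanging one heavy atom, oxygen for nitrogen, is far from silent here. The counts under comparison do not separate the two groups, as hydroxy and amino match in hydrogen-bond donors and acceptors and neither brings a ring or a net charge, so the large step arises with all of these counts unchanged. No measurement on either group speaks to the origin of the step, and the values alone give no explanation for it.

Still open, as far as these compounds go, is how the tolerated concentration responds to other groups on this nitrogen, such as methoxy, methylamino or a longer chain, and so whether amino or hydroxy is the unusual member. Also open, from the compounds shown here alone, is whether the change from hydroxy to amino gives a step of similar size on the shared core of compound 1 and compound 3.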